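Compound 3: from aryl amide back to benzyl amide

A few compounds are considered here, and "the series" means these few. Any claim that something is new, unique, unknown or untested is made for them only; others in the source may bear on it.

Measured in a functional assay on SK-BR-3 cells (Homo sapiens) for inhibition, read by MTT assay; on this read-out lower numbers stand for stronger inhibition of growth and higher numbers for weaker inhibition of growth:
- Compound 1 `CC1=C(/C=C/C(C)=C/C=C/C(C)=C\C(=O)NCc2cccc(F)c2)C(C)(C)CCC1n1ccnc1`: 4240 nM
- Compound 2 `CC1=C(/C=C/C(C)=C/C=C/C(C)=C\C(=O)Nc2ccc(F)cc2)C(C)(C)CCC1n1ccnc1`: 25100 nM

Compound 2 has the higher of the two numbers, so it is the weaker growth inhibitor of this pair. Compound 3 `CC1=C(/C=C/C(C)=C/C=C/C(C)=C\C(=O)NCc2ccc(O)cc2)C(C)(C)CCC1n1ccnc1`, not yet measured, differs from it in one place: 4-hydroxybenzyl in place of 4-fluorophenyl on an amide-type nitrogen. In words, 4-hydroxybenzyl stands in place of 4-fluorophenyl on an amide-type nitrogen.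

Among the compounds with values here, only one measured step bears on this: a 5.9-fold higher number from compound 1 to compound 2 (0.77 log units; beyond the scatter), where 4-fluorophenyl replaced 3-fluorobenzyl at that nitrogen. Compound 3 has a benzyl group, as compound 1 does, so a move back towards the 4240 nM of compound 1 is expected. Within the data shown here, no measured compound carries the 4-hydroxybenzyl group, so the range stays wide. The expected change is a 5.0-fold lower number from compound 2 to compound 3 (0.70 log units; beyond the scatter). For compound 3 the estimated value is 5000 nM, with a range from 1800 nM to 14000 nM.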

Compound 3, concentration for 50% growth inhibition: 2450 nM
The estimate for compound 3 lay 2.0-fold (0.31 log units) above the measured number; measured number inside the range.
By their numbers in this assay, from the lowest: compounds 3 and 1 (each within the scatter of the next); then compound 2.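

In this assay, 4-hydroxybenzyl in place of 4-fluorophenyl on the amide-type nitrogen gives a 10-fold lower number from compound 2 to compound 3 (1.01 log units; beyond the scatter) and so marks a large difference at this position. Replacing 3-fluorophenyl with 4-hydroxyphenyl on the saturated chain carbon gives a 1.7-fold lower number from compound 1 to compound 3 (0.24 log units; within the scatter) and leaves the two benzyl amides level in this assay, so a benzyl group here tolerates either ring pattern shown. Among these three compounds, both benzyl amides give lower numbers than the single aryl amide, and none goes against this.

Still open, from the compounds shown here alone, is how much of the large step belongs to the added chain carbon and how much to the ring group, and whether a longer chain or a carboxylic acid on the ring would keep this level. No measurement shown here explains these differences.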